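The compounds below may be only part of what the source reports. "The series", "measured", "known", "first", "only" and "open" are said of these compounds alone.

Measured compounds:
- compound 1 `Cc1cc(NC(=O)Cn2nnc(-c3ccccc3)n2)n(C2CCCCC2)n1`: 92% in an assay on HEK293 cells for activation of Kir3.1/Kir3.2 (Homo sapiens), read by thallium flux; on this read-out lower numbers stand for smaller maximal responses and higher numbers for larger maximal responses
- compound 2 `Cc1cc(NC(=O)Cn2nnc(-c3ccccc3)n2)n(C2CC2)n1`: > 78% in this assay

Compound 2 stands only at a limit of this assay, > 78%, and no number is known for it. The step that the limit leaves unreadable from compound 1 to compound 2 cannot be read in size, as the limit of > 78% in this assay, at which 1 of the 2 values shown sits, shows. Compound 3 `Cc1cc(NC(=O)Cn2nnc(-c3ccccc3)n2)n(C2CCS(=O)(=O)C2)n1` is not yet measured in this assay; it differs from compound 2 by 1,1-dioxothiolan-3-yl in place of cyclopropyl on an aromatic nitrogen. For the measured compounds named here, no measured step concerns an exchange of this kind, and the single step between measured compounds is unreadable, so nothing in the measured pairs bears on it. What is known is compound 1 at 92%. For compound 2 only the limit is known. On this basis no step beyond the scatter is expected, and a step that the limit leaves unreadable from compound 2 to compound 3 is the estimated step from compound 2 to compound 3. Compound 3 is expected near 85%, within 60% to 100%.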

Compound 3, largest response reached (Emax), in percent of the reference or control that the assay uses: 93%
Estimate against measurement, compound 3: 8 percentage points below; the range from low to high includes it.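

In this assay, placing 1,1-dioxothiolan-3-yl in place of cyclohexyl on the aromatic nitrogen gives a number 1 percentage points higher from compound 1 to compound 3 (within the scatter). This position therefore accepts a five-membered ring with a hetero atom and hydrogen-bond acceptors, and on this read-out that ring cannot be told apart from the all-carbon cyclohexyl ring. Compound 2 has only a limit, > 78%, so cyclopropyl gives no number for comparison, and the steps that involve compound 2 cannot be read: the limit of > 78% in this assay, at which 1 of the 3 values shown sits.

Open, going by these compounds, is whether the maximal response at this position holds with an amine or a carboxylic acid on the ring, or with an open chain such as n-butyl in place of the ring. Also open, on these data alone, is how a plain thiolan-3-yl group would compare with 1,1-dioxothiolan-3-yl.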